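Acetyl for Methyl on a Brominated Diaryl Ether

The source may report more compounds than this note shows. Statements on the series, on what has been measured and on what is new or still open speak of the compounds shown alone.

Of the compounds shown here, three sharing a brominated diaryl ether core have been tested in a functional assay on HL-60 cells (Homo sapiens) for cytotoxicity, read by MTT assay, with a stated time of 24 h; a lower number here means a stronger inhibitor, a higher number a weaker inhibitor. Compound 1 `COc1ccccc1N1CCN(CCCCCOc2c(Br)cc(Br)cc2Oc2ccc(Br)cc2Br)CC1` carries a long chain ending in a piperazine bearing a 2-methoxyphenyl group, and in this assay compound 1 gives 32.2 ug/mL. Compound 3 `CC(C)(C)OC(=O)N1CCN(CCCCCOc2c(Br)cc(Br)cc2Oc2ccc(Br)cc2Br)CC1` has the same chain with a tert-butoxycarbonyl group on the ring nitrogen instead, and in this assay compound 3 gives 32.1 ug/mL. The step of a 1.0-fold lower number from compound 1 to compound 3 (0.00 log units; within the scatter) shows that this swap changed nothing outside the scatter. Compound 2 `COc1c(Br)cc(Br)cc1Oc1ccc(Br)cc1Br` is the bare core with a methoxy group, and in this assay compound 2 gives 28.2 ug/mL, the lowest of the three numbers, though the gaps to compound 3 and compound 1 both fall inside the scatter, so no order can be claimed.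

Compound 4 `CC(=O)Oc1c(Br)cc(Br)cc1Oc1ccc(Br)cc1Br` differs from compound 2 by the change (acetyl in place of methyl on an oxygen on an aromatic ring). Within the data shown here, no measured step touches this oxygen; the single measured step, at a ring nitrogen far out on the chain, was flat. With all three numbers sitting close together, the expected step of a 1.0-fold lower number from compound 2 to compound 4 (0.00 log units; within the scatter) is none beyond the scatter. Compound 4 is therefore estimated at 28 ug/mL, with a range from 14 ug/mL to 56 ug/mL.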

Compound 4, half-maximal inhibitory concentration: 29.9 ug/mL
The estimate for compound 4 lay 1.1-fold (0.03 log units) below the measured number; the measured number falls inside the stated range.
By their numbers in this assay, from the lowest: compounds 2, 4, 3 and 1 (each within the scatter of the next).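

In this assay, among these compounds, the change from methoxy to acetoxy gives a 1.1-fold higher number from compound 2 to compound 4 (0.03 log units; within the scatter), which is the first direct reading at this oxygen on an aromatic ring. Acetyl brings a carbonyl and a hydrogen-bond acceptor that methyl lacks, yet this step cannot be told apart from repeat-measurement noise, just as a 1.0-fold lower number from compound 1 to compound 3 (0.00 log units; within the scatter) could not at the ring nitrogen at the far end of the chain. Neither of the two single-place changes measured so far, at these two distant sites, therefore separates its pair of compounds in this cell assay, and no supporting measurement is available to explain this result.

As far as these compounds go, it remains open whether a group of a different kind on this oxygen, such as a free hydroxyl, a carboxylic acid or a short chain ending in an amine, would give a step beyond the scatter. The compounds shown also do not settle whether changing the bromines on the shared core would move the number, so the parts of the structure that matter for this cytotoxicity remain unidentified.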